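From Diethylamino to Diisopropylamino

The source may report more compounds than this note shows. Statements on the series, on what has been measured and on what is new or still open speak of the compounds shown alone.

In a physicochemical assay for solubility, read by spectrophotometry (a lower number here means a less soluble compound, a higher number a more soluble compound), compound 1 (`CN(C)Cc1c(O)c(O)c(O)c2c(=O)cc(-c3ccc(O)cc3)oc12`) gives 8580 nM and compound 2 (`CCN(CC)Cc1c(O)c(O)c(O)c2c(=O)cc(-c3ccc(O)cc3)oc12`) gives 7710 nM and the two values lie within the scatter of each other. Compound 3 (`CC(C)N(Cc1c(O)c(O)c(O)c2c(=O)cc(-c3ccc(O)cc3)oc12)C(C)C`) carries diisopropylamino in place of diethylamino on a saturated chain carbon bound to an aromatic carbon. Within the data shown here, the only measured step that bears on this is a 1.1-fold lower number from compound 1 to compound 2 (0.05 log units; within the scatter) and it put diethylamino in place of dimethylamino. Going by that step alone, the expected change is a 1.1-fold lower number from compound 2 to compound 3 (0.04 log units; within the scatter) with no shift beyond the scatter. In this assay compound 3 is estimated at 7000 nM with an expected range from 3800 nM to 12000 nM overall.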

Compound 3, solubility: 7970 nM
Beside the measured number, compound 3's estimate is 1.1-fold (0.06 log units) below it; the range from low to high includes it.
By their numbers in this assay, from the lowest: compounds 2, 3 and 1 (each within the scatter of the next).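

In this assay the change to diisopropylamino gives a 1.0-fold higher number from compound 2 to compound 3 (0.01 log units; within the scatter) and the larger change from dimethylamino gives a 1.1-fold lower number from compound 1 to compound 3 (0.03 log units; within the scatter) so even the group with 7 heavy atoms leaves the number within the scatter at this position, on a saturated chain carbon bound to an aromatic carbon. Nothing at hand explains why these numbers stay together. Still open, going by these compounds, is whether a ring amine such as morpholine or piperidine, or a carboxylic acid, at this position would move the number beyond the scatter.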